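The source may report more compounds than this note shows. Statements on the series, on what has been measured and on what is new or still open speak of the compounds shown alone.

Measured so far:
compound 1 `Fc1ccc(C2(c3ccc(F)cc3)CNC(c3cccc(C(F)(F)F)c3)=N2)cc1`: 6.2 nM
compound 2 `Fc1ccc(C2(c3ccc(F)cc3)CNC(c3ccc(C(F)(F)F)cc3)=N2)cc1`: 160 nM
compound 3 `OCc1cccc(C2=NC(c3ccc(F)cc3)(c3ccc(F)cc3)CN2)c1`: 59 nM

Among these three numbers in an assay on LM cells for displacement of a labelled ligand from Neuropeptide Y receptor type 5 (Homo sapiens) (on this read-out lower numbers stand for stronger inhibition and higher numbers for weaker inhibition), compound 3 stands second highest; compound 2 is nearest, compound 1 furthest. Among the measured compounds shown here, the only step that touches the same position, a 9.5-fold higher number from compound 1 to compound 3 (0.98 log units; beyond the scatter), concerns a substituent on the aromatic ring. Compound 4 `N#Cc1cc(C2=NC(c3ccc(F)cc3)(c3ccc(F)cc3)CN2)ccn1` differs from compound 3 by 2-cyanopyridin-4-yl in place of 3-(hydroxymethyl)phenyl on a carbon with a double bond to nitrogen. For the measured compounds named here, no measured step exchanges the whole aromatic ring in this way, so the single step from compound 1 to compound 3 gives only loose guidance. Compound 4 is therefore expected to stay close to compound 3, with an estimated step of a 1.0-fold higher number from compound 3 to compound 4 (0.01 log units; within the scatter) that need not exceed the scatter, giving an estimate of 60 nM within 15 nM to 250 nM.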

Compound 4, half-maximal inhibitory concentration: 4.8 nM
The estimate for compound 4 lay 13-fold (1.10 log units) above the measured number; the whole stated range lies above it.
By their numbers in this assay, from the lowest: compounds 4 and 1 (each within the scatter of the next); then compound 3; then compound 2.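

In this assay, the step of a 12-fold lower number from compound 3 to compound 4 (1.09 log units; beyond the scatter) shows that this carbon, between two ring nitrogen atoms, accepts exchange of the whole aromatic ring, with no hydrogen-bond donor on the entering group. A ring with a hetero atom can therefore stand here without loss: compound 4, at 4.8 nM, lies within the scatter of compound 1, at 6.2 nM. Nothing available explains this change.

Going by these compounds, the ring nitrogen and the nitrile enter together, and their separate shares remain open. Also open, on these data alone, is how a pyridine ring carrying an amine or a carboxylic acid in place of the nitrile would read.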